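Replacing thiophen-2-yl with 3,4,5-trimethoxyphenyl

The source may report more compounds than this note shows. Statements on the series, on what has been measured and on what is new or still open speak of the compounds shown alone.

For the measured compounds named here, in a functional assay on THP-1 cells (Homo sapiens) for inhibition, read by sulforhodamine B assay, with a stated time of 48 h, tested at 50 uM (a higher number here means more inhibition of growth at the concentration tested, a lower number less inhibition of growth), compound 2 `COc1cc(/C=C/C(=O)/C=C/c2cccs2)ccc1OCc1cn(CCCCCOc2cc(=O)oc3ccccc23)nn1` gives 34%, the lowest of the three numbers so far. Compound 1 `COc1cccc(/C=C/C(=O)/C=C/c2ccc(OCc3cn(CCCCOc4cc(=O)oc5ccccc45)nn3)c(OC)c2)c1` gives 47% and compound 3 `COc1cc(/C=C/C(=O)/C=C/c2cc(OC)c(OC)c(OC)c2)ccc1OCc1cn(CCCCOc2cc(=O)oc3ccccc23)nn1` gives 65%, and both lie beyond the scatter from compound 2.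

Compound 4 `COc1cc(/C=C/C(=O)/C=C/c2cc(OC)c(OC)c(OC)c2)ccc1OCc1cn(CCCCCOc2cc(=O)oc3ccccc23)nn1` has not yet been measured. It has 3,4,5-trimethoxyphenyl in place of thiophen-2-yl on a double-bonded chain carbon bound to a double-bonded chain carbon.

Going by the values given here, one measured step bears on this change. The same group entered at the same place in a number 18 percentage points higher from compound 1 to compound 3 (beyond the scatter), a modest rise. Among the compounds with values here, that step replaced 3-methoxyphenyl, however, and no measured step starts from thiophen-2-yl, so it is only a rough guide. An upward step in this assay is therefore expected, of similar or somewhat larger size.

The expected step is a number 23 percentage points higher from compound 2 to compound 4 (beyond the scatter). The estimate for compound 4 is 57%, with an expected range from 43% to 72%.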

Compound 4, percent growth inhibition at one concentration: 55%
The estimate for compound 4 lay 2 percentage points above the measured number, within the range that was stated.
By their numbers in this assay, from the lowest: compound 2; then compounds 1, 4 and 3 (each within the scatter of the next, the first and the last beyond it).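

In this assay, putting 3,4,5-trimethoxyphenyl in place of thiophen-2-yl on a double-bonded chain carbon bound to a double-bonded chain carbon gives a number 21 percentage points higher from compound 2 to compound 4 (beyond the scatter). Alongside a number 18 percentage points higher from compound 1 to compound 3 (beyond the scatter), this makes a second rise beyond the scatter for the same entering group, now from a five-membered sulfur-containing ring rather than 3-methoxyphenyl and on a different linking chain, so the gain at this position does not rest on a single pair. Nothing available explains why this group raises the number.

As far as these compounds go, it remains open whether a plain phenyl, a pyridine ring or a phenyl carrying a carboxylic acid at this place would give a number nearer that of compound 2 or compound 4. From the compounds shown here alone, each number also comes from a single concentration, so how the compounds behave across a range of concentrations remains open.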